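Working notes: from compound 3 to compound 4

A few compounds are considered here, and "the series" means these few. Any claim that something is new, unique, unknown or untested is made for them only; others in the source may bear on it.

Compound 3 `C=CCc1c(OC(C)=O)ccc2ccc(=O)oc12` gives 820 nM in an assay on LNCaP cells for inhibition of 3-oxo-5-alpha-steroid 4-dehydrogenase 1 (Homo sapiens) (on this read-out higher numbers stand for weaker inhibition and lower numbers for stronger inhibition), the second highest of the three numbers. Going by the values given here, compound 2 `C=CCc1c(OC(=O)c2ccccc2)ccc2ccc(=O)oc12` gives 490 nM and compound 1 `C=CC(C)(C)Oc1ccc2ccc(=O)oc2c1` gives 1300 nM; both lie within the scatter of compound 3, and the only single-point step, a 1.7-fold higher number from compound 2 to compound 3 (0.22 log units; within the scatter), is itself within the scatter. Compound 4 `C=CCc1c(OC(C)(C)C=C)ccc2ccc(=O)oc12` differs from compound 3 by 1,1-dimethylprop-2-en-1-yl in place of acetyl on an oxygen on an aromatic ring. Among the compounds with values here, no measured step covers this exchange; compound 1 carries the same entering group on its oxygen but lacks the second chain of compound 3, so its value serves only as a loose anchor. The step of a 1.2-fold higher number from compound 3 to compound 4 (0.09 log units; within the scatter) is therefore expected to be none beyond the scatter. Compound 4 is estimated at 1000 nM, with a range of 400 nM to 2500 nM.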

Compound 4, half-maximal inhibitory concentration: 50300 nM
The estimate for compound 4 lay 50-fold (1.70 log units) below the measured number, outside the stated range (above it).
By their numbers in this assay, from the lowest: compounds 2, 3 and 1 (each within the scatter of the next, the first and the last beyond it); then compound 4.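

On an oxygen on an aromatic ring, 1,1-dimethylprop-2-en-1-yl in place of acetyl gives a 61-fold higher number from compound 3 to compound 4 (1.79 log units; beyond the scatter), so this position responds strongly to this exchange, whereas methyl in place of phenyl on the carbonyl carbon stayed within the scatter. With 1,1-dimethylprop-2-en-1-yl on that oxygen, allyl in place of hydrogen on an aromatic carbon also gives a large step, a 39-fold higher number from compound 1 to compound 4 (1.59 log units; beyond the scatter), so compound 4 stands apart from both its single-change neighbours. Nothing available explains either step. The compounds shown leave open how a hydroxyl or a methoxy group on that oxygen would read with the allyl chain kept.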